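Amide series: from compound 2 to compound 3

The source may report more compounds than this note shows. Statements on the series, on what has been measured and on what is new or still open speak of the compounds shown alone.

Measured in a toxicity assay on L02 cells (Homo sapiens) for inhibition, read by MTT assay, with a stated time of 48 h (a lower number here means a stronger inhibitor, a higher number a weaker inhibitor), each value a limit of the assay:
- compound 1 `CCC(=O)Nc1ccc(N2CCN(c3ccc(OC[C@@H]4CO[C@@](Cn5cncn5)(c5ccc(Cl)cc5Cl)O4)cc3)CC2)cc1`: > 50000 nM
- compound 2 `O=C(CC1CCOCC1)Nc1ccc(N2CCN(c3ccc(OC[C@@H]4CO[C@@](Cn5cncn5)(c5ccc(Cl)cc5Cl)O4)cc3)CC2)cc1`: > 50000 nM

Compound 2 stands only at a limit, > 50000 nM. Among the compounds with values here, neither measured compound gives a number, and the series so far sits at the limit of > 50000 nM in this assay, at which 2 of the 2 values shown sit.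

Compound 3 `O=C(Nc1ccc(N2CCN(c3ccc(OC[C@@H]4CO[C@@](Cn5cncn5)(c5ccc(Cl)cc5Cl)O4)cc3)CC2)cc1)C(/C=C/Cl)C/C=C/C(F)(F)F` is not yet measured. Its change from compound 2 is 1-(2-chloroethenyl)-5,5,5-trifluoropent-3-en-1-yl in place of (oxan-4-yl)methyl on a carbonyl carbon. The incoming group has no ring and carries 2 double bonds outside aromatic rings.

Within the data shown here, the one measured step that bears on this is a step that the two limits leave unreadable from compound 1 to compound 2, which also alters the group on that carbonyl carbon. Its size cannot be read, and it offers no size or direction to carry over. Among the measured compounds shown here, the data hold no measured step to this kind of group.

The expected step is a number no higher from compound 2 to compound 3 (the limit leaves the size open), with none expected beyond the scatter in this assay. Compound 3 is estimated at 50000 nM, with an expected range of 20000 nM to 100000 nM.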

Compound 3, half-maximal inhibitory concentration: > 50000 nM
Compound 3: no number, only a limit; the forecaster's own chance of this, stated with the estimate: 75%; the middle value sits exactly at the limit.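

In this assay compound 3 gives > 50000 nM, which is a limit of the assay and not a number. The steps joining compound 3 to compound 1 and to compound 2 therefore cannot be read, and the series stays at one limit: the limit of > 50000 nM in this assay, at which 3 of the 3 values shown sit.

The compounds shown leave open whether the groups on the carbonyl carbon differ at all in this assay.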